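Trifluoromethoxy for trifluoromethyl on the sulfonyl aryl ring

This account rests on a few compounds, and the source may have more. Where it says the series, first, only, none or still open, it means among the compounds named here.

Compound 1 `CC(O)(CS(=O)(=O)c1ccc(C(F)(F)F)cc1)C(=O)Nc1ccc(S(F)(F)(F)(F)F)cc1` gives 20700 nM in a functional assay on LNCaP cells (Homo sapiens) for antiproliferative activity, read by propidium iodide staining, with a stated time of 96 h; a lower number here means a stronger inhibitor, a higher number a weaker inhibitor. Compound 2 `CC(O)(CS(=O)(=O)c1ccccc1C(F)(F)F)C(=O)Nc1ccc(S(F)(F)(F)(F)F)cc1` gives 10800 nM, and the only step to it, a 1.9-fold lower number from compound 1 to compound 2 (0.28 log units; within the scatter), lies within the scatter, so the two numbers shown are not separated. Compound 3 `CC(O)(CS(=O)(=O)c1ccccc1OC(F)(F)F)C(=O)Nc1ccc(S(F)(F)(F)(F)F)cc1` carries trifluoromethoxy in place of trifluoromethyl on an aromatic carbon. Going by the values given here, no measured step covers this exchange; the single step available moves a trifluoromethyl around the ring rather than replacing it, and it stayed within the scatter. Compound 3 is therefore expected to sit close to compound 2, with a 1.1-fold lower number from compound 2 to compound 3 (0.03 log units; within the scatter) and an estimate of 10000 nM in the range 4000 nM to 25000 nM.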

Compound 3, half-maximal inhibitory concentration: 12700 nM
Estimate against measurement, compound 3: 1.3-fold (0.10 log units) below; low and high end bracket the measured number.
By their numbers in this assay, from the lowest: compounds 2, 3 and 1 (each within the scatter of the next).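

In this assay, trifluoromethoxy on an aromatic carbon ortho to a large group does not separate from trifluoromethyl, with a 1.2-fold higher number from compound 2 to compound 3 (0.07 log units; within the scatter). The 2-(trifluoromethoxy)phenyl on the sulfonyl sulfur likewise does not separate from the 4-(trifluoromethyl)phenyl, with a 1.6-fold lower number from compound 1 to compound 3 (0.21 log units; within the scatter), so all three compounds form one unresolved group of numbers. Nothing available offers an explanation for this result. Still open, from the compounds shown here alone, is whether an amine or a carboxylic acid at this aromatic carbon would move the number beyond the scatter, or whether a plain phenyl on the sulfonyl sulfur would.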